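The source may hold more compounds than are shown below. What is called first, only, known or untested is meant among the compounds shown, and "the series" means these compounds.

Compound 1 `OC[C@@H](O[C@H]1CCCN(Cc2ncc[nH]2)[C@H]1c1ccccc1)c1cc(Cl)cc(Cl)c1` stands second highest among the three numbers obtained in an assay on isolated protein for activation of cGMP-dependent protein kinase 1 (Homo sapiens), read by ADP-Glo, with stated times of 120 min and 40 min (a higher number here means that more compound is needed for the effect, a lower number that less compound is needed), where compound 1 gives 7000 nM. Compound 3 `COC(=O)Nn1c(C[C@H]2CCC[C@H](OCc3cc(C(F)(F)F)cc(C(F)(F)F)c3)[C@@H]2c2ccccc2)n[nH]c1=O` gives 4500 nM in this assay, a value within the scatter of that of compound 1, so no order between the two can be claimed. Compound 2 `Clc1cc(Cl)cc(CO[C@H]2CCCN(Cc3cccnc3)[C@H]2c2ccccc2)c1` gives 112000 nM in this assay, a gap from compound 1 that lies beyond the scatter. Compound 4 `OC[C@@H](O[C@H]1CCCN(Cc2cccc3nonc23)[C@H]1c1ccccc1)c1cc(Cl)cc(Cl)c1` departs from compound 1 by a group of 9 heavy atoms (6 carbon, 2 nitrogen, 1 oxygen; one five-membered aromatic ring with 3 hetero atoms, one six-membered aromatic ring of carbon only) in place of a group of 5 heavy atoms (3 carbon, 2 nitrogen; one five-membered aromatic ring with 2 hetero atoms), on a saturated chain carbon bound to an amine nitrogen in a ring. Going by the values given here, no step between measured compounds covers this change, so the expectation rests on compound 1 alone. A step of a 1.6-fold higher number from compound 1 to compound 4 (0.20 log units; within the scatter) is expected, small and toward a higher number, close to the scatter. For compound 4 a value of 11000 nM is estimated, within the range 3000 nM to 40000 nM.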

Compound 4, half-maximal effective concentration: 8000 nM
Compound 4: the middle estimate sits 1.4-fold (0.14 log units) above what was measured, and the stated range covers the measured number.
By their numbers in this assay, from the lowest: compounds 3, 1 and 4 (each within the scatter of the next); then compound 2.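

At this place, on a saturated chain carbon bound to an amine nitrogen in a ring, the larger group with two aromatic rings replaces 1H-imidazol-2-yl and gives a 1.1-fold higher number from compound 1 to compound 4 (0.06 log units; within the scatter) in this assay. The number thus stays within the scatter although the group grows from 5 to 9 heavy atoms and the entering group has 0 hydrogen-bond donors where the leaving group has 1. No independent measurement available here accounts for this result. As far as these compounds go, whether a carboxylic acid or an aliphatic amine at this place would keep the number in the same range remains open. So does whether a plain phenyl group would do so.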